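The compounds below may be only part of what the source reports. "The series", "measured", "known", "first", "only" and "open" are said of these compounds alone.

Measured so far:
compound 1 `Nc1scc(CN2CCN(c3cccc4ccccc34)CC2)c1C(=O)c1ccc(Cl)cc1`: 0%
compound 2 `Nc1scc(CN2CCN(c3cc(F)ccc3F)CC2)c1C(=O)c1ccc(Cl)cc1`: 2%

In an assay on CHO cells for displacement of a labelled ligand from adenosine receptor A3 (Homo sapiens), read by scintillation counting, with a stated time of 120 min, tested at 10 uM (on this read-out lower numbers stand for less inhibition and higher numbers for more inhibition at the one concentration tested (going by the name of the read-out)), compound 2 gives 2%, the highest of the two numbers, though its nearest neighbour, compound 1, lies within the scatter of it. Going by the values given here, the only measured step is a number 2 percentage points higher from compound 1 to compound 2 (within the scatter). Compound 3 `Nc1scc(CN2CCN(CCCc3ccc(Cl)cc3)CC2)c1C(=O)c1ccc(Cl)cc1` differs from compound 2 by 3-(4-chlorophenyl)propyl in place of 2,5-difluorophenyl on an amine nitrogen in a ring. Among the compounds with values here, no measured step swaps an aryl group on that ring nitrogen for a 3-(4-chlorophenyl)propyl chain, and the one step known, an exchange of aryl groups, stayed within the scatter. The expected step is therefore small, a number 4 percentage points higher from compound 2 to compound 3 (within the scatter). Compound 3 is expected to give 6%, within 0% to 25%.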

Compound 3, a percentage reported as inhibition, at one concentration (the size of the read-out at that concentration, not a potency): 0%
Compound 3: the middle estimate sits 6 percentage points above what was measured; measured number inside the range.
By their numbers in this assay, from the lowest: compounds 1, 3 and 2 (each within the scatter of the next).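

In this assay the 3-(4-chlorophenyl)propyl chain on the amine nitrogen in the ring gives a number 2 percentage points lower from compound 2 to compound 3 (within the scatter) and no change at the digits printed from compound 1 to compound 3 (within the scatter) so the change from an aryl group directly on that nitrogen to an aryl group carried on a chain leaves the number within the scatter. Across naphthalen-1-yl, 2,5-difluorophenyl and this chain, no step at this position leaves the scatter. No evidence at hand bears on these numbers. Open, going by these compounds, is whether a benzyl group or a chain ending in a carboxylic acid on this nitrogen would give a step beyond the scatter.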